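Replacing 2-Ethoxyethyl on the Amine Nitrogen

The source may hold more compounds than are shown below. What is called first, only, known or untested is meant among the compounds shown, and "the series" means these compounds.

For the measured compounds named here, in a functional assay on MV4-11 cells (Homo sapiens) for antiproliferative activity, read by CellTiter-Glo, with a stated time of 72 h (a lower number here means a stronger inhibitor of growth, a higher number a weaker inhibitor of growth), compound 2 `CCOCCN[C@H]1CC[C@H](Nc2cc(-c3csc(NCC4CCOCC4)n3)c(Cl)cn2)CC1` gives 497 nM, the lower of the two numbers measured so far. Going by the values given here, compound 1 `COCCCN[C@H]1CC[C@H](Nc2cc(-c3csc(NCC4CCOCC4)n3)c(Cl)cn2)CC1`, the only other measured compound, gives 1090 nM. Compound 3 `COC[C@@H](C)N[C@H]1CC[C@H](Nc2cc(-c3csc(NCC4CCOCC4)n3)c(Cl)cn2)CC1` has not yet been measured. It keeps the shared core and places 1-(methoxymethyl)ethyl in place of 2-ethoxyethyl on an amine nitrogen. The two compounds have the same atoms, joined differently, and the entering group carries the one defined stereocentre that sets this side chain apart.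

Among the compounds with values here, only one measured step bears on this change: a 2.2-fold lower number from compound 1 to compound 2 (0.34 log units; beyond the scatter). That step also alters the chain on the same amine nitrogen, and it is modest, though beyond the scatter. Within the data shown here, it offers a rough guide to size, but no compound with a group of the entering type has been measured, so the direction remains open. A step of similar or smaller size is therefore expected in this assay, with no firm direction. The estimated step is a 1.2-fold lower number from compound 2 to compound 3 (0.07 log units; within the scatter). Compound 3 is expected at about 420 nM, with an estimated range of 130 nM to 1300 nM.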

Compound 3, concentration for 50% growth inhibition: 140 nM
The estimate for compound 3 lay 3.0-fold (0.48 log units) above the measured number; the range from low to high includes it.
By their numbers in this assay, from the lowest: compound 3; then compound 2; then compound 1.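

The change from 2-ethoxyethyl to 1-(methoxymethyl)ethyl leaves the atoms of the side chain the same and alters only how they are joined, yet in this assay it gives a 3.6-fold lower number from compound 2 to compound 3 (0.55 log units; beyond the scatter), so on this amine nitrogen the arrangement of the chain counts, not just its composition. Set against the 3-methoxypropyl group of compound 1, the same entering group gives a 7.8-fold lower number from compound 1 to compound 3 (0.89 log units; beyond the scatter), and with both of its steps beyond the scatter, compound 3 has the lowest number of the three compounds, which the earlier pair, both with unbranched chains, could not have shown. No measurement is available here that would explain this shift.

The compounds shown leave open how the mirror-image form of 1-(methoxymethyl)ethyl would compare with compound 3, and so whether the defined stereocentre itself matters in this assay. They also leave open whether the ether oxygen of the entering group is needed at all, a question that a plain isopropyl group, a 1-hydroxypropan-2-yl group or a longer branched ether chain on the same amine nitrogen would address.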